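From compound 3 to compound 4: a phenyl swap

The source may hold more compounds than are shown below. What is called first, only, known or untested is meant among the compounds shown, and "the series" means these compounds.

- compound 1 `O=C(/C=C/c1ccc(O)c(O)c1)N1CCN(c2ccc(F)cc2)CC1` gives 1.68 ug/mL
- compound 2 `O=C(/C=C/c1ccc(O)c(O)c1)N1CCN(c2cccc(Cl)c2)CC1` gives 1.71 ug/mL
- compound 3 `O=C(/C=C/c1ccc(O)c(O)c1)N1CCN(c2ccc([N+](=O)[O-])cc2)CC1` gives 1.79 ug/mL

In a functional assay on B16-F10 cells (Mus musculus) for antiproliferative activity, read by MTT assay, with a stated time of 48 h (a higher number here means a weaker inhibitor, a lower number a stronger inhibitor), compound 3 stands level with the other two measured compounds, and a 1.0-fold higher number from compound 1 to compound 2 (0.01 log units; within the scatter) is likewise small.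

Compound 4 `O=C(/C=C/c1ccc(O)c(O)c1)N1CCN(c2ccc(Cl)c(Cl)c2)CC1` carries 3,4-dichlorophenyl in place of 4-nitrophenyl on an amine nitrogen in a ring.

The group at this same place changes in a 1.1-fold higher number from compound 1 to compound 3 (0.03 log units; within the scatter) and in a 1.0-fold higher number from compound 2 to compound 3 (0.02 log units; within the scatter), and neither step leaves the scatter. On that basis the expected step, a 1.1-fold lower number from compound 3 to compound 4 (0.02 log units; within the scatter), is none beyond the scatter in this assay.

Compound 4 is estimated at 1.7 ug/mL, with an expected range of 1.1 ug/mL to 2.7 ug/mL.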

Compound 4, half-maximal inhibitory concentration: 1.66 ug/mL
Beside the measured number, compound 4's estimate is 1.0-fold (0.01 log units) above it, within the range that was stated.
By their numbers in this assay, from the lowest: compounds 4, 1, 2 and 3 (each within the scatter of the next).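

In this assay a second chloro on the aryl group leaves the number level: a 1.0-fold lower number from compound 2 to compound 4 (0.01 log units; within the scatter) is the single-place change of chloro in place of hydrogen on an aromatic carbon. 3,4-Dichlorophenyl also sits level with the other two aryl groups, in a 1.0-fold lower number from compound 1 to compound 4 (0.01 log units; within the scatter) and in a 1.1-fold lower number from compound 3 to compound 4 (0.03 log units; within the scatter). No measured property bears on these level values.

Open, on these data alone, is whether a carboxylic acid or an amine on the phenyl ring, or a benzyl group on the ring nitrogen, would leave the scatter. As far as these compounds go, all four compounds share one core, so changes elsewhere remain untested here.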